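Swapping an Acid for an Amine on the Sulfonyl Arm

The compounds below may be only part of what the source reports. "The series", "measured", "known", "first", "only" and "open" are said of these compounds alone.

Compound 1, `Cn1c(=O)c(S(=O)(=O)c2ccc(C(=O)O)cc2)cc2cnc(Nc3ccc4[nH]ccc4c3)nc21`: 5000 nM in a functional assay on K562 cells (Homo sapiens) for inhibition, read by trypan blue exclusion, with a stated time of 72 h; a higher number here means a weaker inhibitor, a lower number a stronger inhibitor
Compound 2, `Cn1c(=O)c(S(=O)(=O)c2ccc(F)cc2F)cc2cnc(Nc3cccc4[nH]ccc34)nc21`: 1500 nM in this assay
Compound 3, `Cn1c(=O)c(S(=O)(=O)c2ccc(OC(=O)CCCCC3SCC4NC(=O)NC43)cc2)cc2cnc(Nc3ccc4[nH]ccc4c3)nc21`: 600 nM in this assay

The three measured compounds share one core and differ in the group carried on the sulfonyl sulfur, and in other places as well. Among them compound 1 has the highest number, so it is the weakest inhibitor of the three; compound 2 stands nearest to it and compound 3 furthest, and both gaps lie beyond the usual scatter of repeat measurements.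

Compound 4, `Cn1c(=O)c(S(=O)(=O)c2ccc(N)cc2F)cc2cnc(Nc3ccc4[nH]ccc4c3)nc21`, has not yet been measured. It differs from compound 1 in a single place: 4-amino-2-fluorophenyl in place of 4-carboxyphenyl on a sulfonyl sulfur. For the measured compounds named here, no pair of measured compounds differs in only one place, so no measured step guides this change directly. Compounds 2 and 3 both lack the 4-carboxyphenyl and both give lower numbers than compound 1, though each also differs elsewhere.

The step from compound 1 to compound 4 is expected to be a 3.3-fold lower number from compound 1 to compound 4 (0.52 log units; beyond the scatter), a move to a lower number beyond the scatter. Compound 4 is thus estimated at 1500 nM, with a likely range from 400 nM to 5000 nM.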

Compound 4, half-maximal inhibitory concentration: 1500 nM
Compound 4: middle estimate and measured number agree at the digits printed; the measured number falls inside the stated range.
By their numbers in this assay, from the lowest: compound 3; then compounds 2 and 4 (each within the scatter of the next); then compound 1.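

In this assay, putting 4-amino-2-fluorophenyl in place of 4-carboxyphenyl on the sulfonyl sulfur gives a 3.3-fold lower number from compound 1 to compound 4 (0.52 log units; beyond the scatter). For the compounds shown here, this is the first comparison in which only the group on the sulfonyl sulfur changes, so it shows that this group alone can move the number beyond the scatter, something compounds 2 and 3 could not show since each also differs elsewhere. No measurement shown explains why the number moves.

Going by these compounds, the amine and the fluorine enter together, so it remains open how much of the step belongs to each; a phenyl ring carrying only the amine or only the fluorine would separate them. Also open, on these data alone, is how a hydroxyl or a methoxy group would compare on the same ring.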